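This account rests on a few compounds, and the source may have more. Where it says the series, first, only, none or still open, it means among the compounds named here.

Among the three compounds measured in a functional assay on MCF7 cells (Homo sapiens) for inhibition, read by XTT assay, with a stated time of 48 h (on this read-out lower numbers stand for stronger inhibition and higher numbers for weaker inhibition), compound 3 `COc1ccc(C(=O)/C(=C/c2ccc(Cl)cc2Cl)CCOC(C)=O)cc1` gives 83400 nM, the highest number of the set. Compound 1 `CCC(/C=C(\COC(=O)c1ccccc1)C(=O)c1ccc(OC)cc1)CC` gives 28000 nM and compound 2 `COc1ccc(C(=O)/C(=C/C2CCCCC2)COC(=O)c2ccccc2)cc1` gives 13700 nM; both stand beyond the scatter away from compound 3, with compound 2 the furthest. Compound 4 `COc1ccc(C(=O)/C(=C/C2CCCCC2)CCOC(C)=O)cc1` arises from compound 3 by cyclohexyl in place of 2,4-dichlorophenyl on a double-bonded chain carbon bound to a double-bonded chain carbon. For the measured compounds named here, no measured pair swaps an aromatic ring for a saturated ring at this place, and compound 2, which also carries cyclohexyl there, differs from compound 3 in a second place as well, so those two numbers can only be set side by side and not read as a single step. Going by the values given here, the one measured step at the same place, a 2.0-fold lower number from compound 1 to compound 2 (0.31 log units; beyond the scatter), went toward lower numbers when cyclohexyl entered, and compound 2 with its 13700 nM sits well below compound 3. On that basis a modest move toward lower numbers is expected for compound 4 in this assay, estimated as a 3.8-fold lower number from compound 3 to compound 4 (0.58 log units; beyond the scatter). Compound 4 is therefore expected at about 22000 nM, with a range from 7000 nM to 65000 nM, the uncertainty being wide because the aryl-to-cyclohexyl swap itself has not been measured.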

Compound 4, half-maximal inhibitory concentration: > 100000 nM
Compound 4 was reported as a limit; the forecaster's own chance of this, stated with the estimate: 5%; at least 4.5-fold (0.65 log units) between middle value and limit.
By their numbers in this assay, from the lowest: compound 2; then compound 1; then compound 3. At a limit, above all of these: compound 4.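

Compound 4 is reported in this assay only as a limit: the limit of > 100000 nM in this assay, at which 1 of the 4 values shown sits.

For the change at the double-bonded chain carbon bound to a double-bonded chain carbon, the result gives only a floor, an at least 1.1-fold higher number from compound 3 to compound 4 (0.07 log units; that floor lies within the scatter), so cyclohexyl in place of 2,4-dichlorophenyl shows no gain here, and the floor alone does not establish a difference. Cyclohexyl therefore does not set the number by itself: with it held in place, acetoxymethyl in place of benzoyloxy on a saturated chain carbon bound to a double-bonded chain carbon gives an at least 7.2-fold higher number from compound 2 to compound 4 (0.86 log units; beyond the scatter), which shows that this second place, untouched by the earlier step, matters at least as much as the ring.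

The compounds shown leave open how large the step to cyclohexyl really is, and whether benzoyloxy would have the same effect with 2,4-dichlorophenyl as it has with cyclohexyl. They also leave open what an unsubstituted phenyl would do at the double-bonded chain carbon, or an amine or a carboxylic acid in place of the ester on the saturated chain carbon.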